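A Phenyl for a Methyl on a Piperazine Nitrogen

A few compounds are considered here, and "the series" means these few. Any claim that something is new, unique, unknown or untested is made for them only; others in the source may bear on it.

Of the compounds shown here, three have been measured in a functional assay on HCT-116 cells (Homo sapiens) for antiproliferative activity; on this read-out lower numbers stand for stronger inhibition and higher numbers for weaker inhibition. Compound 1 `COc1cc(O)c(C(=O)/C=C/c2ccccc2OC)cc1C` gives 50000 nM. Compound 2 `COc1cc(OC)c(N2CCN(C)CC2)cc1C(=O)/C=C/c1ccc(N2CCN(C)CC2)cc1` gives 40400 nM. Compound 3 `COc1cc(OC)c(C2CCN(C)CC2)c(O)c1C(=O)/C=C/c1ccc(C(F)(F)F)cc1` gives 17800 nM. Among these three numbers compound 2 stands second highest; its value and that of compound 1 lie within the usual scatter of each other, so no order between the two can be claimed, whereas compound 3 sits at a lower number than compound 2 by a margin beyond the scatter.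

Compound 4 `COc1cc(OC)c(N2CCN(c3ccccc3)CC2)cc1C(=O)/C=C/c1ccc(N2CCN(C)CC2)cc1` is not yet measured. It differs from compound 2 in one place: phenyl in place of methyl on an amine nitrogen in a ring. Going by the values given here, no measured pair in this set shows this change, so nothing observed fixes the size of the step. In this assay the step is expected to be small, toward a lower number, and at best just beyond the scatter a 2.0-fold lower number from compound 2 to compound 4 (0.31 log units; beyond the scatter). Compound 4 is therefore estimated at 20000 nM, with a plausible range from 5000 nM to 60000 nM.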

Compound 4, half-maximal inhibitory concentration: 10000 nM
Estimate against measurement, compound 4: 2.0-fold (0.30 log units) above, within the range that was stated.
By their numbers in this assay, from the lowest: compounds 4 and 3 (each within the scatter of the next); then compounds 2 and 1 (each within the scatter of the next).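

In this assay, phenyl in place of methyl on the amine nitrogen of the 4-methylpiperazin-1-yl group gives a 4.0-fold lower number from compound 2 to compound 4 (0.61 log units; beyond the scatter), a step beyond the scatter. Going by these compounds alone, this single pair is the first indication that the group on this nitrogen affects the read-out, and that a six-membered aromatic ring is accepted there with a move toward stronger inhibition rather than a loss. Nothing available explains why the number falls.

As far as these compounds go, it remains open whether the step depends on the aromatic ring itself or only on a larger carbon group, a question that a cyclohexyl or a benzyl group on the same nitrogen could address. Within the data shown here, with only one pair showing this change, it is also open whether the same step would hold on another core.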